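The compounds below may be only part of what the source reports. "The series", "measured", "known", "first", "only" and "open" are said of these compounds alone.

Four compounds share one core and differ only in the side chain that hangs from an amide-type nitrogen. Compound 1 `CC(C)(C)c1ccc(C(=O)N2CCC3(CC2)C(=O)N(CC(=O)N2CCCCC2CCO)CN3c2ccccc2)cc1` carries a hydroxyethyl group on a ring; in an assay on HEK293 cells for displacement of a labelled ligand from NPC1-like intracellular cholesterol transporter 1 (Homo sapiens) (on this read-out lower numbers stand for stronger inhibition and higher numbers for weaker inhibition), compound 1 gives 6100 nM. Compound 2 `CC(C)(C)c1ccc(C(=O)N2CCC3(CC2)C(=O)N(CC(=O)N2CCCCC2CO)CN3c2ccccc2)cc1` carries a hydroxymethyl group at the same place, and in this assay compound 2 gives 11800 nM. For the measured compounds named here, the step of a 1.9-fold higher number from compound 1 to compound 2 (0.29 log units; within the scatter) is the only measured step, and it stays within the usual scatter.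

Compound 3 `COC(=O)CCNC(=O)CN1CN(c2ccccc2)C2(CCN(C(=O)c3ccc(C(C)(C)C)cc3)CC2)C1=O` has an open-chain side arm ending in an ester. For compound 3 the entry in this assay reads "not determined" (no result reported), so compound 3 cannot be placed against compound 1 or compound 2. Compound 4 `CC(C)(C)c1ccc(C(=O)N2CCC3(CC2)C(=O)N(CC(=O)NCCCNS(C)(=O)=O)CN3c2ccccc2)cc1` differs from compound 3 by one change: (methanesulfonamido)methyl in place of methoxycarbonyl on a saturated chain carbon, two bonds along the chain from an amide-type nitrogen.

Going by the values given here, no measured step concerns this kind of exchange, and the one measured step, between compound 1 and compound 2, touches a different part of the molecule. What the numbers of compound 1 and compound 2 do show is that this series sits in a weak range. On that basis alone, compound 4 is expected to give about 8000 nM in this assay, with a plausible span from 2500 nM to 25000 nM.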

Compound 4, half-maximal inhibitory concentration: 10400 nM
Estimate against measurement, compound 4: 1.3-fold (0.11 log units) below; low and high end bracket the measured number.
By their numbers in this assay, from the lowest: compounds 1, 4 and 2 (each within the scatter of the next).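

In this assay, for the compounds shown here, compound 4 provides the first number for an open-chain side arm, and that arm cannot be told apart from the ring-bearing ones: (3-(methanesulfonamido)propyl)amino in place of 2-(hydroxymethyl)piperidin-1-yl on a carbonyl carbon gives a 1.1-fold lower number from compound 2 to compound 4 (0.05 log units; within the scatter) and the same group in place of 2-(2-hydroxyethyl)piperidin-1-yl gives a 1.7-fold higher number from compound 1 to compound 4 (0.23 log units; within the scatter) in this comparison. At this position, then, a ring carrying a hydroxyl-bearing chain and an open chain ending in a methanesulfonamide read alike, and all three compounds stay in the same weak range. No supporting data are available to explain this similarity.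

On these data alone, the step from compound 3 to compound 4 cannot be read, compound 3 having no number, so the direct exchange of methoxycarbonyl for (methanesulfonamido)methyl remains open. Also open, as far as these compounds go, is whether a side arm ending in a primary amine or a carboxylic acid, or a longer chain than 3-(methanesulfonamido)propyl, would move the number beyond the scatter in this assay at this position.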